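The compounds below may be only part of what the source reports. "The series", "measured", "known", "first", "only" and "open" are said of these compounds alone.

Among the compounds with values here, compound 1 `CNc1cc(Oc2c(OC)cc3cc(C#N)ccc3c2OC)nc(Nc2ccc(C#N)cc2)n1` is the only member of this group with a number rather than a limit: in an ADME assay on MT4 cells (Homo sapiens) for cytotoxicity, read by MTT assay, with a stated time of 5 days (on this read-out lower numbers stand for higher toxicity in this test and higher numbers for lower toxicity in this test), compound 1 gives 239000 nM as its read-out. Compound 2 `COc1cc2cc(C#N)ccc2c(OC)c1Oc1cc(NCC(C)(C)C)nc(Nc2ccc(C#N)cc2)n1` differs from it by tert-butyl in place of hydrogen on a saturated chain carbon bound to a nitrogen on an aromatic ring, and compound 3 `COc1cc2cc(C#N)ccc2c(OC)c1Oc1cc(NCC2CC2)nc(Nc2ccc(C#N)cc2)n1` by cyclopropyl in place of hydrogen on a saturated chain carbon bound to a nitrogen on an aromatic ring. For compound 2 the read-out in this assay is a limit of the assay, namely > 125000 nM in that test. For compound 3 the read-out in this assay is likewise a limit, namely > 125000 nM in that test. The steps a step that the limit leaves unreadable from compound 1 to compound 2 and a step that the limit leaves unreadable from compound 1 to compound 3 therefore cannot be sized, nor can a step that the two limits leave unreadable from compound 2 to compound 3 be sized; all that is visible is the limit of > 125000 nM in this assay, at which 2 of the 3 values shown sit, for the series.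

Compound 4 `COc1cc2cc(C#N)ccc2c(OC)c1Oc1cc(NC2CCCC2)nc(Nc2ccc(C#N)cc2)n1` is the unmeasured member and differs from compound 1 by cyclopentyl in place of methyl on a nitrogen on an aromatic ring on the shared core. Within the data shown here, no measured step bears directly on this change, and the steps at the saturated chain carbon were left unreadable by the limit. Since compound 1 already sits at 239000 nM, compound 4 is expected to show no step beyond the scatter in this assay, that is a 1.2-fold lower number from compound 1 to compound 4 (0.08 log units; within the scatter) in that test. The estimated value for compound 4 is 200000 nM with an expected range from 100000 nM to 400000 nM.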

Compound 4, half-maximal cytotoxic concentration: > 125000 nM
Compound 4 was reported as a limit (the forecaster's own chance of this, stated with the estimate: 50%); the middle value lies beyond the limit too.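

Within the data shown here, with compound 4 reported as a limit in this assay, no step linking it to compound 1, compound 2 or compound 3 can be read: the limit of > 125000 nM in this assay, at which 3 of the 4 values shown sit. On these data alone, whether the groups on the nitrogen in compound 2, compound 3 and compound 4 set these compounds apart from compound 1, or from one another, in this assay stays open.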